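A few compounds are considered here, and "the series" means these few. Any claim that something is new, unique, unknown or untested is made for them only; others in the source may bear on it.

Compound 1 `CC1=C(N2CC2)C(=O)C(CCCOC(N)=O)=C(N2CC2)C1=O`: 5.55
Compound 2 `CCC1=C(N2CC2)C(=O)C(CCOC(N)=O)=C(N2CC2)C1=O`: 5.98

Both numbers come from a functional assay on L1210 cells (Mus musculus), with a stated time of 1 days; a higher number here means a more potent compound, by a factor of ten per unit of this negative logarithm, a lower number a less potent compound. Of the two measured compounds, compound 1 stands lowest; compound 2 gives a number higher by a margin beyond the usual scatter of repeated measurements. Compound 3 `CC(=O)C1=C(N2CC2)C(=O)C(C)=C(N2CC2)C1=O` has not yet been measured. It differs from compound 1 in one place: a group of 3 heavy atoms (2 carbon, 1 oxygen; no ring) in place of a group of 7 heavy atoms (4 carbon, 1 nitrogen, 2 oxygen; no ring), on a double-bonded ring carbon. Among the measured compounds shown here, no step between two measured compounds shows what such a change does, so the expectation rests on compound 1 alone. A small downward step is expected, a number 0.15 log units lower from compound 1 to compound 3 (within the scatter), of a size that repeated measurements could blur. Compound 3 is therefore estimated at 5.4, with a range from 4.7 to 6.1.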

Compound 3, logarithm of the reciprocal of the active concentration, log(1/C): 3.94
Compound 3: middle estimate off by 1.46 log units, on the high side; the whole stated range lies above it.
By their numbers in this assay, from the lowest: compound 3; then compound 1; then compound 2.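

At this position on a double-bonded ring carbon, the choice of group matters strongly: in this assay, acetyl in place of the group of 7 heavy atoms gives a number 1.61 log units lower from compound 1 to compound 3 (beyond the scatter) and so marks the change as far from neutral. Compound 1 and compound 2 alone could not show this. No measurement here explains the drop. Still open, from the compounds shown here alone, is whether the drop follows the loss of the larger group or the arrival of acetyl, and how a chain ending in an amine or a carboxylic acid would fare here.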